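Swapping methoxy for trifluoromethyl: expected toxicity on Vero cells

The compounds below may be only part of what the source reports. "The series", "measured", "known", "first", "only" and "open" are said of these compounds alone.

Compound 2 `COc1ccc(-c2ccc([C@@H](c3ccccc3)[C@@](O)(CCN(C)C)c3cccc4ccccc34)c(OC)n2)cc1` has been tested in a toxicity assay on Vero cells (Chlorocebus sabaeus) for cytotoxicity; on this read-out lower numbers stand for higher toxicity in this test and higher numbers for lower toxicity in this test. In this assay compound 2 gives > 50 ug/mL, which is a limit of the measurement rather than a number. Compound 1 `COc1nc(-c2ccsc2)ccc1[C@@H](c1ccccc1)[C@@](O)(CCN(C)C)c1cccc2ccccc12` carries a thiophen-3-yl group where compound 2 carries a 4-methoxyphenyl group. In this assay, for the measured compounds named here, compound 1 gives 24.4 ug/mL, and the step of an at least 2.0-fold higher number from compound 1 to compound 2 (0.31 log units; beyond the scatter) is the only measured step so far; its size rests on (the limit of > 50 ug/mL in this assay, at which 1 of the 2 values shown sits).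

Compound 3 `COc1nc(-c2ccc(C(F)(F)F)cc2)ccc1[C@@H](c1ccccc1)[C@@](O)(CCN(C)C)c1cccc2ccccc12` is the next compound, not yet measured. It differs from compound 2 in one place: trifluoromethyl in place of methoxy on an aromatic carbon. Going by the values given here, none of the measured steps concerns this exchange, so there is nothing in the data that points to a clear direction for it. The expectation is therefore a step of an at least 1.4-fold lower number from compound 2 to compound 3 (0.15 log units; that floor lies within the scatter), with wide uncertainty on either side. Compound 3 is estimated to give about 35 ug/mL in this assay, within a range from 12 ug/mL to 60 ug/mL.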

Compound 3, half-maximal cytotoxic concentration: > 50 ug/mL
Compound 3 gave a limit, no number (the forecaster's own chance of this, stated with the estimate: 40%); middle value at least 1.4-fold (0.15 log units) from the limit.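

In this assay compound 3 gives > 50 ug/mL, which is a limit of the assay and not a number. Replacing thiophen-3-yl with 4-(trifluoromethyl)phenyl gives an at least 2.0-fold higher number from compound 1 to compound 3 (0.31 log units; beyond the scatter), so a second phenyl group with a different substituent now shares the shift to lower toxicity in this test that 4-methoxyphenyl showed, and neither of these two compounds goes against it within this set of three. The direct exchange of methoxy for trifluoromethyl cannot be read, because both compounds rest on the limit, not on a number: the limit of > 50 ug/mL in this assay, at which 2 of the 3 values shown sit.

For the compounds shown here, how far compound 2 and compound 3 each lie beyond that limit stays unknown, so any real difference between methoxy and trifluoromethyl in this test could be hidden, and the only firm comparison at this position remains the one against thiophen-3-yl. As far as these compounds go, it also stays open whether a phenyl group with no substituent, or one carrying an amine or a carboxylic acid in the same place, would reach the limit as well, or would fall closer to the value of the thiophene compound.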